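The source may report more compounds than this note shows. Statements on the series, on what has been measured and on what is new or still open speak of the compounds shown alone.

Working notes on the series, read in a functional assay on DU-145 cells (Homo sapiens) for inhibition, read by trypan blue exclusion, with a stated time of 96 h; a lower number here means a stronger inhibitor of growth, a higher number a weaker inhibitor of growth. Compound 1 `O=C(O)c1ccc(C(=O)/C(=C\c2ccc(Cl)c([N+](=O)[O-])c2)SCc2ccc(Br)cc2)cc1` gives 500 nM, compound 2 `O=C(O)c1ccc(C(=O)/C(=C\c2ccc(Br)c([N+](=O)[O-])c2)SCc2ccc(Br)cc2)cc1` gives 1000 nM, and compound 3 `CN1CCN(/C=C(/SCc2ccc(Br)cc2)C(=O)c2ccc(C(=O)O)cc2)CC1[N+](=O)[O-]` gives 10000 nM, the highest number of the three. Compound 4 `O=C(O)c1ccc(C(=O)/C(=C\c2ccccc2F)SCc2ccc(Br)cc2)cc1` differs from compound 3 as follows: 2-fluorophenyl in place of 4-methyl-3-nitropiperazin-1-yl on a double-bonded chain carbon bound to a double-bonded chain carbon. This places 2-fluorophenyl in place of 4-methyl-3-nitropiperazin-1-yl on a double-bonded chain carbon bound to a double-bonded chain carbon.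

Among the measured compounds shown here, two measured steps bear on this change, in the opposite direction: a 20-fold higher number from compound 1 to compound 3 (1.30 log units; beyond the scatter) and a 10-fold higher number from compound 2 to compound 3 (1.00 log units; beyond the scatter). Both are beyond the scatter. The halogen swap, a 2.0-fold higher number from compound 1 to compound 2 (0.30 log units; within the scatter), is within it. For the measured compounds named here, no measured compound carries 2-fluorophenyl, so a similar drop in this assay is only an expectation. The expected step is a 10-fold lower number from compound 3 to compound 4 (1.00 log units; beyond the scatter). Compound 4 is estimated at 1000 nM, with an expected range of 300 nM to 4000 nM.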

Compound 4, concentration for 50% growth inhibition: 10000 nM
Compound 4: middle estimate off by 10-fold (1.00 log units), on the low side; the whole stated range lies below it.
By their numbers in this assay, from the lowest: compounds 1 and 2 (each within the scatter of the next); then compounds 3 and 4 (each within the scatter of the next).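

In this assay, 2-fluorophenyl on a double-bonded chain carbon bound to a double-bonded chain carbon reads the same as 4-methyl-3-nitropiperazin-1-yl (no change at the digits printed from compound 3 to compound 4 (within the scatter)). An aromatic ring of carbon at this place therefore does not by itself match the halogenated nitrophenyl groups (a 10-fold higher number from compound 2 to compound 4 (1.00 log units; beyond the scatter); a 20-fold higher number from compound 1 to compound 4 (1.30 log units; beyond the scatter)). Nothing available gives a cause for this result.

Open, going by these compounds, is whether the nitro group or the halogen accounts for the gap. A 3-nitrophenyl without halogen and a 4-chlorophenyl without nitro would separate the two.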